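A few compounds are considered here, and "the series" means these few. Any claim that something is new, unique, unknown or untested is made for them only; others in the source may bear on it.

Three compounds share one core and differ only in the ring attached to it. Compound 1 `O=Cc1cn(-c2ccccc2)nc1-c1ccc([N+](=O)[O-])cc1` carries a nitro group on that ring, compound 2 `O=Cc1cn(-c2ccccc2)nc1-c1ccccc1O` a hydroxy group, and compound 3 `O=Cc1cn(-c2ccccc2)nc1-c1cccc([N+](=O)[O-])c1` a nitro group at another position. In a functional assay on MCF7 cells (Homo sapiens) for antiproliferative activity, read by MTT assay, with a stated time of 24 h, tested at 0.1 ug/mL (on this read-out higher numbers stand for a weaker effect at the one concentration tested and lower numbers for a stronger effect), compound 1 gives 96%, compound 2 gives 73%, and compound 3 gives 86%. Among these three numbers, compound 1 stands highest; the gap to compound 3 lies within the usual scatter of such measurements, while the gap to compound 2 lies beyond it. Within the data shown here, no pairwise comparison between the measured compounds has been worked out, so the only guide is the spread of these numbers.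

Compound 4 `O=Cc1cn(-c2ccccc2)nc1-c1ccc(Cl)cc1` is the one still to be tested. It differs from compound 1 by a single exchange: chloro in place of nitro on an aromatic carbon. Given how close the two nitro compounds sit, a step in this assay of modest size is expected, if any beyond the scatter, toward a somewhat stronger effect. The estimated step from compound 1 to compound 4 is a number 8 percentage points lower from compound 1 to compound 4 (within the scatter). Compound 4 is therefore expected to give about 88%, within a range from 72% to 100%.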

Compound 4, a percentage reported as activity, at one concentration (the size of the read-out at that concentration, not a potency): 90%
Compound 4: middle estimate off by 2 percentage points, on the low side; the range from low to high includes it.
By their numbers in this assay, from the lowest: compound 2; then compounds 3, 4 and 1 (each within the scatter of the next).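

Among these compounds, the first step that can be read in a single place, chloro in place of nitro on an aromatic carbon para to a large group, is a number 6 percentage points lower from compound 1 to compound 4 (within the scatter) in this assay. Among the compounds shown here, at this position, then, the nitro group and its hydrogen-bond acceptors can give way to chloro, which counts none, without a step beyond the scatter; the earlier compounds, which differ from one another in more than one respect, could not show this. No measurement shown accounts for this result.

Going by these compounds, whether an amine or a carboxylic acid on this same carbon would give a step beyond the scatter remains open. On these data alone, how compound 1 and compound 4 would compare at other concentrations also remains open.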